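The compounds below may be only part of what the source reports. "The series", "measured", "known", "first", "only" and "open" are said of these compounds alone.

Compound 2 `CCOc1nc(N)c2nc(O)n(Cc3ccccc3)c2n1` carries an ethoxy group on the shared core. Among the compounds with values here, in a functional assay on the whole organism for activation, with Mus musculus as the target (on this read-out lower numbers stand for an effect already at smaller amounts and higher numbers for an effect only at larger amounts of compound), compound 2 gives 0.3 mg/kg, the higher of the two numbers known so far. Within the data shown here, its only measured neighbour, compound 1 `CCCSc1nc(N)c2nc(O)n(Cc3ccccc3)c2n1`, in which propylsulfanyl stands in place of ethoxy, gives 0.1 mg/kg in this assay; that change is a 3.0-fold higher number from compound 1 to compound 2 (0.48 log units; beyond the scatter). Compound 3 `CCCCCOc1nc(N)c2nc(O)n(Cc3ccccc3)c2n1` has not yet been measured. It differs from compound 2 by propyl in place of hydrogen on a saturated chain carbon, two bonds along the chain from an oxygen on an aromatic ring. Among the measured compounds shown here, no measured step concerns lengthening the chain on the same oxygen, and the one step known also swaps the atom that joins the chain to the ring, so it bears on compound 3 only loosely: compound 1, with its longer chain, shows the lower number. Compound 3 is therefore expected to show at most a modest change, a 1.5-fold lower number from compound 2 to compound 3 (0.18 log units; within the scatter), estimated at 0.2 mg/kg with a range from 0.05 mg/kg to 1 mg/kg.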

Compound 3, minimum effective dose: 0.3 mg/kg
Compound 3: middle estimate off by 1.5-fold (0.18 log units), on the low side; the range from low to high includes it.
By their numbers in this assay, from the lowest: compound 1; then compounds 2 and 3 (each within the scatter of the next).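

In this assay, the longer chain on the oxygen gives no change at the digits printed from compound 2 to compound 3 (within the scatter) so going from ethoxy to pentyloxy leaves the minimum effective dose unchanged at the digits printed. The gap to the sulfur-linked compound also remains, with a 3.0-fold higher number from compound 1 to compound 3 (0.48 log units; beyond the scatter) and this shows that the longer chain of pentyloxy does not reach the lower number of compound 1. No measurement shown gives a reason for either result.

Still open, going by these compounds, is whether the gap follows the linking atom or the particular chain, a question that propoxy, with the chain of compound 1 on oxygen, and pentylsulfanyl, with the chain of compound 3 on sulfur, would help separate. Also open, on these data alone, is how this position would respond to a chain ending in an amine or a carboxylic acid.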